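A few compounds are considered here, and "the series" means these few. Any claim that something is new, unique, unknown or untested is made for them only; others in the source may bear on it.

Two compounds of the shared core carry a number in an assay on isolated protein for displacement of a labelled ligand from 5-hydroxytryptamine receptor 6 (Homo sapiens), read by scintillation counting, with a stated time of 1 h (a higher number here means a weaker inhibitor, a lower number a stronger inhibitor), so far. Compound 1 `COc1ccc2c(ccn2S(=O)(=O)c2ccccc2)c1` gives 127 nM there, and compound 2 `CN1CCN(c2ccc3c(ccn3S(=O)(=O)c3ccccc3)c2)CC1` gives 27 nM. Within the data shown here, compound 2 therefore stands at the lowest number of the two, separated from compound 1 by a 4.7-fold lower number from compound 1 to compound 2 (0.67 log units; beyond the scatter), the only measured step in the set.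

The next member, compound 3 `CC(=O)N1CCN(c2ccc3c(ccn3S(=O)(=O)c3ccccc3)c2)CC1`, differs from compound 2 by acetyl in place of methyl on an amine nitrogen in a ring. Among the measured compounds shown here, no measured step bears directly on this change; the one step in hand, from compound 1 to compound 2, concerns the group on an aromatic carbon and leaves the ring nitrogen untouched, so it gives no guide to the size or direction here. With the amine in the ring changed in this way, compound 3 is expected to move to a higher number, a step of a 5.6-fold higher number from compound 2 to compound 3 (0.74 log units; beyond the scatter). The expected value for compound 3 in this assay is 150 nM, within the range 40 nM to 600 nM.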

Compound 3, inhibition constant: 4850 nM
For compound 3 the middle estimate is 32-fold (1.51 log units) below the measured one, and the stated range ends below it.
By their numbers in this assay, from the lowest: compound 2; then compound 1; then compound 3.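

In this assay the group on the amine nitrogen in the ring has a large effect: acetyl in place of methyl gives a 180-fold higher number from compound 2 to compound 3 (2.25 log units; beyond the scatter) and so reverses the gain that 4-methylpiperazin-1-yl brought over methoxy. The six-membered ring alone therefore does not secure a lower number, since 4-acetylpiperazin-1-yl in place of methoxy gives a 38-fold higher number from compound 1 to compound 3 (1.58 log units; beyond the scatter) and leaves compound 3 the highest of the three. No measurement at hand accounts for the size of this step.

The compounds shown leave open whether a hydrogen, an ethyl group or a longer alkyl chain on that nitrogen would stay close to compound 2. They also leave open whether a carbonyl-free group of the same size as acetyl, such as isopropyl, would give a number closer to that of compound 2 or of compound 3.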